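The source may hold more compounds than are shown below. What is called first, only, known or untested is meant among the compounds shown, and "the series" means these compounds.

Three analogues share the core of compound 1 `C=CCn1c(=O)/c(=C\c2cccc(F)c2)[nH]c(=O)/c1=C\c1ccccc1OC`, which in a functional assay on A549 cells (Homo sapiens) for cytotoxicity, read by CCK-8 assay, with a stated time of 72 h (on this read-out lower numbers stand for stronger inhibition and higher numbers for weaker inhibition), gives 19700 nM. Compound 2 `C=CCn1c(=O)/c(=C\c2cccc(Br)c2)[nH]c(=O)/c1=C\c1ccccc1OC` gives 5400 nM, and compound 3 `C=CCn1c(=O)/c(=C\c2ccccc2C(F)(F)F)[nH]c(=O)/c1=C\c1ccccc1OC` gives 7000 nM. Compound 3 stands second highest of the three numbers: a 2.8-fold lower number from compound 1 to compound 3 (0.45 log units; beyond the scatter), whereas a 1.3-fold higher number from compound 2 to compound 3 (0.11 log units; within the scatter). Compound 4 `C=CCn1c(=O)/c(=C\c2cc(F)ccc2C)[nH]c(=O)/c1=C\c1ccccc1OC` carries 5-fluoro-2-methylphenyl in place of 2-(trifluoromethyl)phenyl on a double-bonded chain carbon bound to an aromatic carbon. Among the measured compounds shown here, the steps that bear on this change are a 2.8-fold lower number from compound 1 to compound 3 (0.45 log units; beyond the scatter) and a 1.3-fold higher number from compound 2 to compound 3 (0.11 log units; within the scatter), both modest or within the scatter, and the fluoro-bearing compound 1 sits at the high end. Compound 4 is therefore expected to show a step of a 1.3-fold higher number from compound 3 to compound 4 (0.11 log units; within the scatter), in the direction of a somewhat higher number, but not clearly beyond the scatter. The estimate for compound 4 is 9000 nM, with a range from 3500 nM to 25000 nM.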

Compound 4, half-maximal inhibitory concentration: 4900 nM
Compound 4: middle estimate off by 1.8-fold (0.26 log units), on the high side, and the stated range covers the measured number.
By their numbers in this assay, from the lowest: compounds 4, 2 and 3 (each within the scatter of the next); then compound 1.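

In this assay, methyl in place of hydrogen on an aromatic carbon gives a 4.0-fold lower number from compound 1 to compound 4 (0.60 log units; beyond the scatter), so a fluoro-bearing aryl group at this place need not sit at the high end. The 5-fluoro-2-methylphenyl group cannot be told apart from 2-(trifluoromethyl)phenyl, with a 1.4-fold lower number from compound 3 to compound 4 (0.15 log units; within the scatter), or from 3-bromophenyl, with a 1.1-fold lower number from compound 2 to compound 4 (0.04 log units; within the scatter), as both steps lie within the scatter. Nothing measured here accounts for these numbers.

Going by these compounds, whether the methyl gives the same step on an aryl group without fluoro remains open. So does the effect of an amine or a carboxylic acid on this aryl group.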